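Compound 3 to compound 4: piperazine aryl swap

The source may report more compounds than this note shows. Statements on the series, on what has been measured and on what is new or still open speak of the compounds shown alone.

Measured in a functional assay on MCF7 cells (Homo sapiens) for antiproliferative activity, read by sulforhodamine B assay, with a stated time of 72 h; on this read-out lower numbers stand for stronger inhibition and higher numbers for weaker inhibition:
- compound 1 `OC[C@H]1O[C@@H](n2cnc3c(N4CCN(C5CCCCC5)CC4)ncnc32)[C@H](O)[C@@H]1O`: "not active" (no number reported)
- compound 2 `OC[C@H]1O[C@@H](n2cnc3c(N4CCN(c5ncccn5)CC4)ncnc32)[C@H](O)[C@@H]1O`: 40000 nM
- compound 3 `Nc1nc(N2CCN(c3ncccn3)CC2)c2ncn([C@@H]3O[C@H](CO)[C@@H](O)[C@H]3O)c2n1`: "not active" (no number reported)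

Only compound 2 has a number in this assay. Compound 3 is recorded as "not active" (no number reported), so it has no single value, and compound 1 is likewise recorded without one. Among the compounds with values here, no step between measured compounds can be read from this set, and any comparison with compound 3 stays qualitative.

Compound 4 `Cc1ccc(N2CCN(c3nc(N)nc4c3ncn4[C@@H]3O[C@H](CO)[C@@H](O)[C@H]3O)CC2)cc1` is the next structure to be tested. The change is 4-methylphenyl in place of pyrimidin-2-yl on an amine nitrogen in a ring. Within the data shown here, the data hold no example of this exchange, so the expected step in this assay is modest: at best a move from no reported number to a weak measurable one, with no large gain. Among the measured compounds shown here, that expectation rests on compound 2 at 40000 nM, the only number available. A result without a number, as for compound 3, remains quite possible. Compound 4 is expected at 30000 nM, with an estimated range from 8000 nM to 100000 nM.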

Compound 4, half-maximal inhibitory concentration: "not active" (no number reported)
For compound 4 the study gives words and no number; the estimate stays without a comparison.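

In this assay compound 3 gives "not active" (no number reported) and compound 4 gives "not active" (no number reported) with no single value on either side, so no step can be read between them. No available evidence bears on this result. The compounds shown leave open whether 4-methylphenyl and pyrimidin-2-yl differ at all on this core.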